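The source may report more compounds than this note shows. Statements on the series, on what has been measured and on what is new or still open speak of the compounds shown alone.

Measured in a functional assay on Bel-7402 cells (Homo sapiens) for antiproliferative activity, read by MTT assay, with a stated time of 72 h; a lower number here means a stronger inhibitor, a higher number a weaker inhibitor:
- compound 1 `C=C1C(=O)O[C@H]2[C@H]1CC/C(COC(=O)Cn1cc(F)c(=O)[nH]c1=O)=C\CC[C@@]1(C)O[C@@H]21`: > 20000 nM
- compound 2 `C=C1C(=O)O[C@H]2[C@H]1CC/C(COC(=O)CCC(=O)NCCCCCCNC(=O)Cn1cc(F)c(=O)[nH]c1=O)=C\CC[C@@]1(C)O[C@@H]21`: > 20000 nM
- compound 3 `C=C1C(=O)O[C@H]2[C@H]1CC/C(COC(=O)CCC(=O)N1CCN(C(=O)Cn3cc(F)c(=O)[nH]c3=O)CC1)=C\CC[C@@]1(C)O[C@@H]21`: > 20000 nM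

Each of these readings is a limit, not a number. Compound 1 stands at the limit of > 20000 nM in this assay, at which 3 of the 3 values shown sit. Among the measured compounds shown here, the series therefore offers no numeric step to build on.

Compound 4 `C=C1C(=O)O[C@H]2[C@H]1CC/C(COC(=O)Cn1cc(F)c(=O)n(Cc3cccc(F)c3)c1=O)=C\CC[C@@]1(C)O[C@@H]21` keeps the core of compound 1 and differs in one place: 3-fluorobenzyl in place of hydrogen on an aromatic nitrogen. This is 3-fluorobenzyl in place of hydrogen on an aromatic nitrogen.

In this assay, a modest move towards stronger inhibition is expected, though another reading at the limit remains quite possible. The expected change is an at least 1.6-fold lower number from compound 1 to compound 4 (0.22 log units; that floor lies within the scatter). Compound 4 is estimated at 12000 nM, with an expected range of 3000 nM to 40000 nM.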

Compound 4, half-maximal inhibitory concentration: 2530 nM
Beside the measured number, compound 4's estimate is 4.7-fold (0.68 log units) above it, and the stated range ends above it.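

In this assay, among the compounds shown here, 3-fluorobenzyl in place of hydrogen on the aromatic nitrogen gives the only numeric reading: an at least 7.9-fold lower number from compound 1 to compound 4 (0.89 log units; beyond the scatter). This position can therefore carry a large group and still move the series off the limit. The true size of the step stays unknown, as only a floor can be read: the limit of > 20000 nM in this assay, at which 3 of the 4 values shown sit.

As far as these compounds go, whether the change depends on the fluoro group, the benzyl ring or simply on replacing the hydrogen stays open. Unsubstituted benzyl or methyl at this nitrogen would separate these readings.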